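Notes on the benzyl step from compound 1

The source may report more compounds than this note shows. Statements on the series, on what has been measured and on what is new or still open speak of the compounds shown alone.

Compound 1 `CCC(CC)C(/C=C1\OC(=O)NC1=O)c1ccc(-c2ccc3cccc(F)c3c2)[nH]c1=O` is the reference point for this step. In an ADME assay on microsomes from liver (Rattus norvegicus) for metabolic stability (on this read-out higher numbers stand for a longer-lived compound and lower numbers for a shorter-lived compound), compound 1 gives > 3 h, which is a limit of the assay and not a number. Compound 1 stands at the limit of > 3 h in this assay, at which 2 of the 3 values shown sit. Compound 2 `O=C1NC(=O)/C(=C/C2(c3ccc(-c4ccc5cccc(F)c5c4)[nH]c3=O)CCCC2)O1` gives > 3 h, which is also a limit. Compound 3 `CC(C)C(c1ccc(-c2ccc3cccc(F)c3c2)[nH]c1=O)C1C(=O)NC(=O)N1C` has a numerical value in this assay, at 0.263 h. Among the measured compounds shown here, no two measured compounds differ in one place only, so these data give no direct measure of the effect of a single change.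

Compound 4 `O=C1NC(=O)/C(=C/C(Cc2ccccc2)c2ccc(-c3ccc4cccc(F)c4c3)[nH]c2=O)O1` is still to be measured. It differs from compound 1 as follows: benzyl in place of pentan-3-yl on a saturated chain carbon bound to an aromatic carbon and a double-bonded chain carbon. This places benzyl in place of pentan-3-yl on a saturated chain carbon bound to an aromatic carbon and a double-bonded chain carbon.

A modest shortening is expected in this assay, although no change beyond the scatter remains possible. The expectation starts from compound 1, whose limit of > 3 h leaves its true value open. The expected change is an at least 1.5-fold lower number from compound 1 to compound 4 (0.17 log units; that floor lies within the scatter). For compound 4 the estimated half-life is 2 h, with an expected range of 0.7 h to 6 h.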

Compound 4, half-life: 2.96 h
Beside the measured number, compound 4's estimate is 1.5-fold (0.17 log units) below it, and the stated range covers the measured number.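

Among the compounds shown here, compound 4 is the first compound here that differs from compound 1 in one place only, so the saturated chain carbon bound to an aromatic carbon and a double-bonded chain carbon can now be read directly. With benzyl in place of pentan-3-yl, this assay gives an at least 1.0-fold lower number from compound 1 to compound 4 (0.00 log units; that floor lies within the scatter), so the data establish no shortening beyond the scatter, and a group carrying a six-membered aromatic ring can stand at this position with a numerical half-life still being obtained. The true size of the step stays open, because the value of compound 1 is a limit of the assay and not a number: the limit of > 3 h in this assay, at which 2 of the 4 values shown sit.

For the compounds shown here, compounds 2 and 3 differ from compound 4 in more than one place, so they add nothing to the reading of this change, and the single step cannot say whether the aromatic ring, the two extra carbons or the loss of branching matters. From the compounds shown here alone, how a phenethyl chain, a cyclohexylmethyl group, an amine or a carboxylic acid at this carbon would behave in this assay remains open.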